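Swapping Phenyl for Benzyl(methyl)amino on a Shared Core

The source may hold more compounds than are shown below. What is called first, only, known or untested is meant among the compounds shown, and "the series" means these compounds.

Compound 1 `CCCCn1cc(C(=O)NCc2ccccc2)c(=O)c2cc(F)c(-c3ccccc3)cc21` was examined in an ADME assay on J774.1 cells (Mus musculus) for cytotoxicity, read by resazurin assay, with a stated time of 48 h; on this read-out higher numbers stand for weaker inhibition and lower numbers for stronger inhibition. In this assay compound 1 gives > 100000 nM, which is a limit of the assay and not a number. Compound 2 `CCCn1cc(C(=O)O)c(=O)c2cc(F)c(N3CCC(C(N)=O)CC3)cc21` likewise shows only a limit in this assay, at > 100000 nM. Compound 3 `CCCCn1cc(C(=O)NCc2ccc([N+](=O)[O-])cc2)c(=O)c2cc(F)c(N3CCC(C(N)=O)CC3)cc21` also returns only a limit in this assay, at > 100000 nM. Compound 1 therefore stands with the other two at the limit of > 100000 nM in this assay, at which 3 of the 3 values shown sit, and no order among the three compounds can be read from these values.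

Compound 4 `CCCCn1cc(C(=O)NCc2ccccc2)c(=O)c2cc(F)c(N(C)Cc3ccccc3)cc21` has not yet been measured in this assay. It differs from compound 1 by benzyl(methyl)amino in place of phenyl on an aromatic carbon. Within the data shown here, no two measured compounds differ in a single place, so no measured step guides the expectation. Because all three values shown sit at the limit of > 100000 nM in this assay, at which 3 of the 3 values shown sit, the expected step of a number no higher from compound 1 to compound 4 (the limit leaves the size open) is none beyond the scatter. Compound 4 is accordingly estimated at 100000 nM, within a range from 30000 nM to 300000 nM, and most probably it will again be reported only as a limit.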

Compound 4, half-maximal inhibitory concentration: 86000 nM
Compound 4: the middle estimate sits 1.2-fold (0.07 log units) above what was measured; low and high end bracket the measured number.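

In this assay, benzyl(methyl)amino in place of phenyl on an aromatic carbon, ortho to a fluoro group, gives an at least 1.1-fold lower number from compound 1 to compound 4 (0.06 log units; that floor lies within the scatter). Compound 4, at 86000 nM, carries the first figure in this set that is a number and not a limit of the assay, so a change at this one position is enough to bring the reading within the range of the assay. The true size of the step stays unknown because it starts from a limit: the limit of > 100000 nM in this assay, at which 3 of the 4 values shown sit.

The compounds shown do not separate the part played by the nitrogen from that of the benzyl group, since no smaller amine such as dimethylamino or a ring amine such as morpholine stands at this position on the core of compound 1. They also leave open whether a larger aromatic group, such as naphthyl, would move the reading further.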